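The source may report more compounds than this note shows. Statements on the series, on what has been measured and on what is new or still open speak of the compounds shown alone.

Working notes on the series. Compound 1 `NS(=O)(=O)Oc1ccc2c(c1)CN(C(=O)c1cccc(N3CCN(c4ncccn4)CC3)c1)CC2` and compound 2 `CCN(Cc1ccccn1)c1ccc(C(=O)N2CCc3ccc(OS(N)(=O)=O)cc3C2)cc1` have both been tested in an assay on HEK293 cells for inhibition of Steryl-sulfatase (Homo sapiens), tested at 0.1 uM; a lower number here means a weaker effect, a higher number a stronger effect of the compound at the concentration tested. In this assay compound 1 gives 1.6%, while compound 2 gives 42.5%, the higher of the two numbers, with a gap to compound 1 that lies beyond the scatter. Compound 3 `CCN(Cc1ccc(F)cc1)c1ccc(C(=O)N2CCc3ccc(OS(N)(=O)=O)cc3C2)cc1` remains to be measured; it differs from compound 2 by 4-fluorophenyl in place of pyridin-2-yl on a saturated chain carbon bound to a nitrogen on an aromatic ring. Going by the values given here, no measured pair carries this change, so the expected step is a number 4.5 percentage points lower from compound 2 to compound 3 (within the scatter), within the scatter and in no settled direction. Compound 3 is estimated at 38%, between 12% and 62%.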

Compound 3, a percentage reported as inhibition, at one concentration (the size of the read-out at that concentration, not a potency): 69.1%
The estimate for compound 3 lay 31.1 percentage points below the measured number; measured number above the stated range.
By their numbers in this assay, from the lowest: compound 1; then compound 2; then compound 3.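

In this assay, the step of a number 26.6 percentage points higher from compound 2 to compound 3 (beyond the scatter) shows that the group on a saturated chain carbon bound to a nitrogen on an aromatic ring affects the read-out, and that 4-fluorophenyl and pyridin-2-yl are not interchangeable at this place. The change swaps a ring nitrogen for carbon and also adds a fluorine, and the pair cannot separate these two parts. No measurement at hand accounts for the step. The compounds shown leave open how plain phenyl or 4-chlorophenyl would read at this place, and whether pyridin-3-yl would behave like pyridin-2-yl.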